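Extending the methoxy group of compound 2

The compounds below may be only part of what the source reports. "The series", "measured", "known", "first", "only" and "open" are said of these compounds alone.

Measured compounds:
compound 1 `COc1cc(C2=C(c3ccc(OCC(=O)O)cc3)C(O)CC2=O)cc(OC)c1OC`: "not determined" (no result reported)
compound 2 `COc1ccc(C2=C(c3cc(OC)c(OC)c(OC)c3)C(=O)CC2O)cc1`: 3.38 ug/mL

Going by the values given here, in an ADME assay on PA-1 cells (Homo sapiens) for cytotoxicity, read by MTT assay, with a stated time of 72 h (on this read-out higher numbers stand for weaker inhibition and lower numbers for stronger inhibition), compound 2 gives 3.38 ug/mL as the only number so far. Compound 1 has no reported result, so compound 2 cannot yet be ranked against anything and stands alone as the reference point.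

The next compound to be tested is compound 3 `CCOC(=O)COc1ccc(C2=C(c3cc(OC)c(OC)c(OC)c3)C(=O)CC2O)cc1`, which keeps the shared core of compound 2. The structural difference is ethoxycarbonyl in place of hydrogen on a saturated chain carbon bound to an oxygen on an aromatic ring. In words, ethoxycarbonyl sits in place of hydrogen on a saturated chain carbon bound to an oxygen on an aromatic ring, so methoxy becomes (ethoxycarbonyl)methoxy.

Among the compounds with values here, no pair of measured compounds shows what such a change does, and the expectation therefore rests on compound 2 at 3.38 ug/mL alone. In this assay no step beyond the usual scatter is expected, with only a slight lean toward weaker inhibition. The estimated change is a 1.5-fold higher number from compound 2 to compound 3 (0.17 log units; within the scatter) and remains an expectation with wide uncertainty. For compound 3 the expected value is 5 ug/mL with an estimated range from 1.5 ug/mL to 15 ug/mL.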

Compound 3, half-maximal inhibitory concentration: > 100 ug/mL
Compound 3 ended at the assay's limit; the forecaster's own chance of this, stated with the estimate: 10%; middle value at least 20-fold (1.30 log units) from the limit.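

In this assay, putting ethoxycarbonyl on the saturated chain carbon bound to an oxygen on an aromatic ring gives an at least 29-fold higher number from compound 2 to compound 3 (1.47 log units; beyond the scatter). Compound 3 stands at a limit of the assay, so this step gives a lower bound on the change and not its exact size: the limit of > 100 ug/mL in this assay, at which 1 of the 3 values shown sits. With compound 2 as the only number before this result, nothing had shown how this position responds to substitution, and the change from methoxy to (ethoxycarbonyl)methoxy now shows that it is far from indifferent in this assay.

With only this one change to read, the compounds shown do not tell whether the weaker inhibition belongs to the ethoxycarbonyl group as a whole, to its carbonyl, to its ethyl part, or simply to the greater length of the group on that oxygen. An amide or an amine at the end of the chain, or a plain longer alkyl chain on the same oxygen, would be needed to tell these readings apart and to show whether any extension of the methoxy group is tolerated.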